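Tert-butyl in place of ethynyl: notes on the next step

The source may hold more compounds than are shown below. What is called first, only, known or untested is meant among the compounds shown, and "the series" means these compounds.

In a functional assay on MDA-MB-231 cells (Homo sapiens) for antiproliferative activity, read by MTT assay, with a stated time of 72 h (a higher number here means a weaker inhibitor, a lower number a stronger inhibitor), compound 1 `O=C(CCc1cccc2c1B(O)OC2)Nc1ccccc1` gives 230 nM and compound 2 `C#Cc1ccc(NC(=O)CCc2cccc3c2B(O)OC3)cc1` gives 6600 nM, so compound 2 holds the higher, weaker number of the two. Compound 3 `CC(C)(C)c1ccc(NC(=O)CCc2cccc3c2B(O)OC3)cc1` keeps the shared core and changes one group: tert-butyl in place of ethynyl on an aromatic carbon. The group stands on an aromatic carbon of a six-membered aromatic ring of carbon only, para to a large group.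

Among the compounds with values here, one measured step bears on this change, at the same aromatic carbon: a 29-fold higher number from compound 1 to compound 2 (1.46 log units; beyond the scatter), a large step beyond the scatter. Within the data shown here, it shows that the number in this assay can move far with the group at this carbon, but it tells nothing directly about tert-butyl, and no compound carrying that group has a measurement yet. With compound 2 at 6600 nM, the high end of a two-compound series, a partial move back towards compound 1 seems more likely than a further rise, though this is weakly supported. The expected change is moderate, an estimated 3.7-fold lower number from compound 2 to compound 3 (0.56 log units; beyond the scatter). Compound 3 is expected at 1800 nM, with an estimated range of 350 nM to 9000 nM.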

Compound 3, half-maximal inhibitory concentration: 33000 nM
Estimate against measurement, compound 3: 18-fold (1.26 log units) below; measured number above the stated range.
By their numbers in this assay, from the lowest: compound 1; then compound 2; then compound 3.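

In this assay, tert-butyl in place of ethynyl does not move the number back towards compound 1: the change gives a 5.0-fold higher number from compound 2 to compound 3 (0.70 log units; beyond the scatter) and so extends the rise seen with ethynyl. Measured against hydrogen at the same aromatic carbon, tert-butyl gives a 140-fold higher number from compound 1 to compound 3 (2.16 log units; beyond the scatter) and is the largest step in the series, so both groups tried at this carbon stand well on the weak side of compound 1, and the number now rises in the order hydrogen, ethynyl, tert-butyl, which is also the order of heavy atoms in the group, a pattern resting on these three compounds alone, with none of them going against it. Nothing at hand gives a measured reason for either step, so that order remains a description and not an explanation.

From the compounds shown here alone, whether the heavy-atom count truly tracks the number stays open, and a methyl, a methoxy, an amine or a carboxylic acid at this carbon would test it with groups of other kinds. Also open, going by these compounds, is whether any group at this carbon can match or better hydrogen in compound 1.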